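The source may hold more compounds than are shown below. What is called first, only, known or untested is meant among the compounds shown, and "the series" means these compounds.

Measured in an ADME assay on microsomes from liver (Rattus norvegicus) for metabolic stability (on this read-out lower numbers stand for a less stable compound and higher numbers for a more stable compound), each value a limit and not a number:

Compound 1 `CCCCCOC(=O)N1CCN(C(=O)[C@H](CCC(=O)O)NC(=O)c2cc(N3CCC(C(=O)N(CC)CC)CC3)nc(-c3ccccc3)n2)CC1`: > 80%
Compound 2 `CCCCCOC(=O)N1CCN(C(=O)[C@H](CCC(=O)O)NC(=O)c2cc(N3CCC(OCCO)CC3)nc(-c3ccccc3)n2)CC1`: > 80%
Compound 3 `CCCCCOC(=O)N1CCN(C(=O)[C@H](CCC(=O)O)NC(=O)c2cc(N3CCC(COC)CC3)nc(-c3ccccc3)n2)CC1`: > 80%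

Compound 3 stands at the limit of > 80% in this assay, at which 3 of the 3 values shown sit. Compound 4 `CCCCCOC(=O)N1CCN(C(=O)[C@H](CCC(=O)O)NC(=O)c2cc(N3CCC(C(=O)N4CCCC4)CC3)nc(-c3ccccc3)n2)CC1` carries (pyrrolidin-1-yl)carbonyl in place of methoxymethyl on a saturated ring carbon. The closest measured change is a step that the two limits leave unreadable from compound 1 to compound 3, with methoxymethyl in place of diethylcarbamoyl. Two further changes at this carbon are a step that the two limits leave unreadable from compound 1 to compound 2 and a step that the two limits leave unreadable from compound 2 to compound 3. None of the three has a size that can be read, yet compounds 1, 2 and 3 all share one limit, so no step beyond the scatter and no direction is expected. The expected change is a step that the limit leaves unreadable from compound 3 to compound 4. For compound 4 the estimate is 88%, with an expected range from 74% to 100%.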

Compound 4, percent of the compound remaining: > 80%
Compound 4: no number, only a limit; the forecaster's own chance of this, stated with the estimate: 70%; the middle value lies beyond the limit too.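

No step from compound 1, compound 2 or compound 3 to compound 4 can be read in this assay, as each value is only a limit: the limit of > 80% in this assay, at which 4 of the 4 values shown sit.

As far as these compounds go, how these four compounds differ in stability past that limit stays open.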